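This account rests on a few compounds, and the source may have more. Where it says the series, first, only, none or still open, it means among the compounds named here.

Values in a functional assay on HeLa cells (Homo sapiens) for antiproliferative activity, read by CCK-8 assay, with a stated time of 72 h; a lower number here means a stronger inhibitor, a higher number a weaker inhibitor:
compound 1 `CCSc1ccc(-c2cncnc2-c2cc(OC)c(OC)c(OC)c2)cc1`: 370 nM
compound 2 `CCOc1ccc(-c2cncnc2-c2cc(OC)c(OC)c(OC)c2)cc1`: 250 nM
compound 3 `CCOc1ccc(-c2cncnc2-c2cc(OC)c(OC)c(OC)c2)cc1Cl`: 90 nM

Compound 2 holds the middle one of these three numbers. Its nearest neighbour is compound 1, with a 1.5-fold lower number from compound 1 to compound 2 (0.17 log units; within the scatter). Compound 3 lies further off, with a 2.8-fold lower number from compound 2 to compound 3 (0.44 log units; beyond the scatter).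

Compound 4 `COc1cc(-c2ncncc2-c2ccc(Br)cc2)cc(OC)c1OC` is still to be measured in this assay. Against compound 2 it carries bromo in place of ethoxy on an aromatic carbon, para to a large group, so that 4-ethoxyphenyl becomes 4-bromophenyl: bromo in place of ethoxy on an aromatic carbon.

Among the measured compounds shown here, two measured steps bear on this change, neither directly. Ethoxy in place of ethylsulfanyl at that same carbon gave a 1.5-fold lower number from compound 1 to compound 2 (0.17 log units; within the scatter), so the one replacement seen there stayed within the scatter. Chloro in place of hydrogen gave a 2.8-fold lower number from compound 2 to compound 3 (0.44 log units; beyond the scatter), a modest step, but there the ethoxy stayed, and compound 4 lacks it. For the measured compounds named here, no measured compound shows bromo or the loss of ethoxy.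

No step beyond the scatter is therefore expected in this assay, and no direction is firm. The working expectation is a 1.1-fold higher number from compound 2 to compound 4 (0.05 log units; within the scatter). For compound 4 the estimated value is 280 nM, with an expected range from 90 nM to 850 nM.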

Compound 4, half-maximal inhibitory concentration: 500 nM
The estimate for compound 4 lay 1.8-fold (0.25 log units) below the measured number; measured number inside the range.
By their numbers in this assay, from the lowest: compound 3; then compounds 2, 1 and 4 (each within the scatter of the next).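

In this assay, at this carbon para to a large group, bromo gives a 2.0-fold higher number from compound 2 to compound 4 (0.30 log units; within the scatter) and a 1.4-fold higher number from compound 1 to compound 4 (0.13 log units; within the scatter), so neither step from ethoxy or ethylsulfanyl to bromo leaves the scatter. The hydrogen-bond acceptor counted on ethoxy is absent from bromo, and with only 1 heavy atom in place of the 3 of ethoxy, the change to 4-bromophenyl still gives no step beyond the scatter, so ethoxy is not shown to be required at this carbon in this assay. Nothing on hand bears on a cause for this result.

Still open, going by these compounds, is whether the chloro of compound 3, whose step a 2.8-fold lower number from compound 2 to compound 3 (0.44 log units; beyond the scatter) was read with ethoxy present, would give a similar step alongside bromo. Also open, on these data alone, is whether an amine, a carboxylic acid, a longer alkoxy chain such as butoxy, or plain hydrogen at this carbon would stay within the scatter of ethoxy, ethylsulfanyl and bromo or would separate from them.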